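The compounds below may be only part of what the source reports. "The series", "measured", "known", "first", "only" and "open" are said of these compounds alone.

Compound 3 `Clc1cc(Cl)cc(CO[C@H]2CCCN(Cc3ncc[nH]3)[C@H]2c2ccccc2)c1` gives 47000 nM in an assay on isolated protein for activation of cGMP-dependent protein kinase 1 (Homo sapiens), read by ADP-Glo, with stated times of 120 min and 40 min (a lower number here means that less compound is needed, a higher number that more compound is needed for the effect), the highest of the two numbers shown. Compound 2 `OC[C@@H](O[C@H]1CCCN(Cc2ncc[nH]2)[C@H]1c1ccccc1)c1cc(Cl)cc(Cl)c1` gives 7000 nM, and the step of a 6.7-fold higher number from compound 2 to compound 3 (0.83 log units; beyond the scatter) separates the two. Compound 1 `Clc1cc(Cl)cc(CO[C@H]2CCCN(Cc3ccccn3)[C@H]2c2ccccc2)c1` reaches only the assay limit of > 200000 nM. Compound 4 `Clc1cc(Cl)cc(CO[C@H]2CCCN(Cc3ccc(-c4nn[nH]n4)cc3)[C@H]2c2ccccc2)c1` differs from compound 3 by 4-(2H-tetrazol-5-yl)phenyl in place of 1H-imidazol-2-yl on a saturated chain carbon bound to an amine nitrogen in a ring. Among the measured compounds shown here, the one measured step at that place, an at least 4.2-fold lower number from compound 1 to compound 3 (0.62 log units; beyond the scatter), shows that the group there matters, though it rests on a limit (the limit of > 200000 nM in this assay, at which 1 of the 3 values shown sits). A larger group carrying a 2H-tetrazol-5-yl ring is a change of another kind, so compound 4 is expected to stay close to compound 3, with a step of a 1.1-fold higher number from compound 3 to compound 4 (0.03 log units; within the scatter), and an estimated 50000 nM, between 10000 nM and 200000 nM.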

Compound 4, half-maximal effective concentration: 74000 nM
Compound 4: middle estimate off by 1.5-fold (0.17 log units), on the low side; the range from low to high includes it.
By their numbers in this assay, from the lowest: compound 2; then compounds 3 and 4 (each within the scatter of the next). At a limit, above all of these: compound 1.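

With the larger group on a saturated chain carbon bound to an amine nitrogen in a ring, the result is a 1.6-fold higher number from compound 3 to compound 4 (0.20 log units; within the scatter), so this position takes 4-(2H-tetrazol-5-yl)phenyl as well as 1H-imidazol-2-yl. Set against pyridin-2-yl, the same group gives an at least 2.7-fold lower number from compound 1 to compound 4 (0.43 log units; beyond the scatter), so a second group now separates from pyridin-2-yl. That step rests on a limit of the assay for compound 1: the limit of > 200000 nM in this assay, at which 1 of the 4 values shown sits.

From the compounds shown here alone, it remains open whether a carboxylic acid in place of the 2H-tetrazol-5-yl ring would give a similar number. Also open, going by these compounds, is whether the hydroxymethyl group of compound 2 would lower the number when combined with 4-(2H-tetrazol-5-yl)phenyl.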